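The source may report more compounds than this note shows. Statements on the series, on what has been measured and on what is new or still open speak of the compounds shown alone.

Working notes on the series. Of the compounds shown here, two have numbers so far in a physicochemical assay for lipophilicity; a lower number here means a more polar compound, a higher number a more lipophilic compound: compound 1 (`COCCN(C1CCN(Cc2c(-c3ccccc3)[nH]c3c(OC)cccc23)C1)S(C)(=O)=O`) gives 2.8, and compound 2 (`O=S(=O)(NC1CCN(Cc2ccncc2)CC1)c1ccc(-n2cccn2)cc1`) gives 2.6. These two values lie within the scatter of each other, so compound 2 cannot be separated from compound 1 on present data. Going by the values given here, the two structures differ in more than one place, and no single-change step is available as a reference.

Next in line is compound 3 (`Cc1cc(-n2cccn2)ccc1S(=O)(=O)NC1CCN(Cc2ccncc2)CC1`), which differs from compound 2 by methyl in place of hydrogen on an aromatic carbon, ortho to a large group and meta to a 1H-pyrazol-1-yl group. Among the compounds with values here, no measured pair shows this change, so the expectation rests on the structural change alone, starting from compound 2 at 2.6. A small rise in this assay is expected. The expected size is a number 0.30 log units higher from compound 2 to compound 3 (within the scatter), which may not be resolved from the scatter. Compound 3 is estimated at 2.9, with an expected range of 2.5 to 3.3.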

Compound 3, distribution coefficient: 2.3
The estimate for compound 3 lay 0.60 log units above the measured number, outside the stated range (below it).
By their numbers in this assay, from the lowest: compounds 3, 2 and 1 (each within the scatter of the next, the first and the last beyond it).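

The single-change step for methyl in place of hydrogen on an aromatic carbon, ortho to a large group and meta to a 1H-pyrazol-1-yl group, reads a number 0.30 log units lower from compound 2 to compound 3 (within the scatter) in this assay. Going by these compounds alone, this is the first reading of a single change, and it shows that adding this one carbon at this position does not separate the two compounds, so no rise beyond the scatter appears for this change in this setting. No measurement at hand bears on the reason for this reading, and a single pair within the scatter cannot show whether the methyl has any real effect here.

As far as these compounds go, whether the same reading holds for methyl on another aromatic carbon of that ring, or in a compound without the 1H-pyrazol-1-yl group, remains open. Also open, from the compounds shown here alone, is what a different group at this position, such as ethyl, methoxy, an amine or a carboxylic acid, would give in this assay, and whether any such step would lie beyond the scatter.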